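Changing One Side Chain on Compound 3

The source may report more compounds than this note shows. Statements on the series, on what has been measured and on what is new or still open speak of the compounds shown alone.

Measured so far:
compound 1, `CCOC(=O)CN(c1nc(Cl)nc2c1ncn2C1CCCCO1)C1CC1`, gives 13% in a functional assay on the whole organism with Mus musculus as the target, with a stated time of 90 min, at a dose of 25 umol/kg by the oral route; a lower number here means a weaker effect, a higher number a stronger effect of the compound at the dose given;
compound 2, `O=C(O)CN(c1nc(Cl)nc2c1ncn2C1CCCCO1)C1CC1`, gives 8.22%;
compound 3, `NC(=O)CC[C@H](NC(=O)CN(c1nc(Cl)nc2c1ncn2C1CCCCO1)C1CC1)C(=O)OCc1ccccc1`, gives 37.8%.

Compound 3 stands highest of the three numbers. Its nearest neighbour is compound 1, whose value lies lower by more than the usual scatter, and compound 2 lies further away still, also beyond the scatter. Among the measured compounds shown here, the only step between two compounds that differ in a single place is a number 4.8 percentage points lower from compound 1 to compound 2 (within the scatter), a change too small to count.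

Compound 4, `CC(C)C[C@H](NC(=O)CN(c1nc(Cl)nc2c1ncn2C1CCCCO1)C1CC1)C(=O)OCc1ccccc1`, has not yet been measured in this assay. It differs from compound 3 by isopropyl in place of carbamoylmethyl on a saturated chain carbon, two bonds along the chain from an amide-type nitrogen and a carbonyl carbon. For the measured compounds named here, no measured step bears on this part of the molecule: the step from compound 1 to compound 2 alters the ester end of the short chain on the shared core, while the side chain that changes here is untouched in every measured compound. Going by the values given here, the measured data therefore give no direction for this step. A group with one donor and one acceptor leaves and a group with neither enters, so the expected step from compound 3 to compound 4 is a number 7.8 percentage points lower from compound 3 to compound 4 (within the scatter), a modest move that may not clear the scatter. Compound 4 is estimated at 30%, with a range from 12% to 50%.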

Compound 4, a percentage reported as activity, at one dose (the size of the read-out at that dose, not a potency): 28.2%
Estimate against measurement, compound 4: 1.8 percentage points above; the range from low to high includes it.
By their numbers in this assay, from the lowest: compounds 2 and 1 (each within the scatter of the next); then compounds 4 and 3 (each within the scatter of the next).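

In this assay, among the compounds shown here, the first measured change to this side chain reads a number 9.6 percentage points lower from compound 3 to compound 4 (within the scatter) and so does not separate the two compounds. Carbamoylmethyl carries a hydrogen-bond donor and a hydrogen-bond acceptor while isopropyl carries neither, yet on this saturated chain carbon, two bonds along the chain from an amide-type nitrogen and a carbonyl carbon, the swap leaves no difference that can be told from the usual scatter, so compound 4 shows that a read-out of this size does not depend on having the amide end of the 2-carbamoylethyl side chain there. No measurement at hand accounts for this result, so why the two side chains read alike stays unexplained.

The compounds shown hold only these two side chains at this place, which is too few to show whether the position tolerates most groups or only these. An amine or a carboxylic acid at the end of the side chain, a longer chain than isobutyl, or a phenyl ring in its place could each still move the number beyond the scatter, in either direction.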